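The compounds below may be only part of what the source reports. "The series", "measured", "known", "first", "only" and "open" are said of these compounds alone.

Compound 3, `COc1ccc2nc(C(=O)Nc3c(F)cc(-c4cccc(F)c4)cc3F)c(C)c(C(=O)O)c2c1`, is one of three measured analogues built on a shared core. In a functional assay on A-375 cells (Homo sapiens) for antiproliferative activity, read by MTT assay, with a stated time of 24 h, tested at 1.23 ug/mL (on this read-out lower numbers stand for a weaker effect and higher numbers for a stronger effect at the one concentration tested), compound 3 gives 10.2%. Compound 2, `Cc1c(C(=O)Nc2c(F)cc(-c3cccc(F)c3)cc2F)nc2ccc(F)cc2c1C(=O)O`, gives 16.3%, and compound 1, `Cc1ccc2nc(C(=O)Nc3c(F)cc(-c4cccc(F)c4)cc3F)c(C)c(C(=O)O)c2c1`, gives 3.65%. Compound 3 therefore stands second highest of the three, but its nearest neighbour is within the scatter: a number 6.1 percentage points lower from compound 2 to compound 3 (within the scatter), and so is its furthest: a number 6.6 percentage points higher from compound 1 to compound 3 (within the scatter). Within the data shown here, only one step stands beyond the scatter, a number 12.7 percentage points higher from compound 1 to compound 2 (beyond the scatter).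

Compound 4, `Cc1c(C(=O)Nc2c(F)cc(-c3cccc(F)c3)cc2F)nc2ccc(C(F)(F)F)cc2c1C(=O)O`, differs from compound 3 at the same aromatic carbon as these exchanges, (trifluoromethyl in place of methoxy on an aromatic carbon). Among the measured compounds shown here, no measured step swaps methoxy for trifluoromethyl, so the closest guides are the two within-scatter steps into compound 3 from compound 1 and compound 2. On that basis a step in this assay of a number 0.8 percentage points higher from compound 3 to compound 4 (within the scatter) is expected, that is, no change beyond the scatter. The estimate for compound 4 in this assay is 11%, with a range from 1% to 24%.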

Compound 4, a percentage reported as inhibition, at one concentration (the size of the read-out at that concentration, not a potency): 18.3%
Compound 4: the middle estimate sits 7.3 percentage points below what was measured; measured number inside the range.
By their numbers in this assay, from the lowest: compounds 1, 3, 2 and 4 (each within the scatter of the next, the first and the last beyond it).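

At this aromatic carbon, trifluoromethyl joins fluoro as a second group that clears the scatter against methyl in this assay, with a number 14.7 percentage points higher from compound 1 to compound 4 (beyond the scatter) as the step. Trifluoromethyl cannot be told apart from the other two groups, however, since both a number 8.1 percentage points higher from compound 3 to compound 4 (within the scatter) and a number 2 percentage points higher from compound 2 to compound 4 (within the scatter) leave it level with methoxy and fluoro, so the larger group with no hydrogen-bond acceptor adds no separate gain that can be read here. Nothing measured alongside these numbers accounts for the steps at this position.

On these data alone, whether an amine or a nitrile on this aromatic carbon would stand with methyl or with trifluoromethyl stays open. Also open, as far as these compounds go, is whether the gap between compound 1 and compound 4 would hold at another concentration or time.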